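A few compounds are considered here, and "the series" means these few. Any claim that something is new, unique, unknown or untested is made for them only; others in the source may bear on it.

Compound 1 `CCOC(=O)c1sc2nc(SC)nc(-c3cccc(OC)c3)c2c1N`: 1.5%
Compound 2 `COc1cccc(-c2nc(SC)nc3sc(C(=O)N(C)C(C)(C)C)c(N)c23)c1`: 3.6%
Compound 3 `COc1cccc(-c2nc(SC)nc3sc(C(=O)NCCO)c(N)c23)c1`: 2.9%

In a functional assay on HEK293 cells for agonist activity at Thyrotropin receptor (Homo sapiens), read by cAMP accumulation (on this read-out lower numbers stand for smaller maximal responses and higher numbers for larger maximal responses), compound 1 stands lowest of the three numbers, though both neighbours lie within the scatter: the step of a number 1.4 percentage points higher from compound 1 to compound 3 (within the scatter) is the nearer one and the step of a number 2.1 percentage points higher from compound 1 to compound 2 (within the scatter) the further one. Compound 4 `COc1cccc(-c2nc(SC)nc3sc(C(=O)NNC(=O)OC(C)(C)C)c(N)c23)c1` differs from compound 1 on the carbonyl carbon alone: ((tert-butoxycarbonyl)amino)amino in place of ethoxy on a carbonyl carbon.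

Two measured steps also exchange the ethoxy group on that carbonyl carbon, a number 2.1 percentage points higher from compound 1 to compound 2 (within the scatter) and a number 1.4 percentage points higher from compound 1 to compound 3 (within the scatter), and the step of a number 0.7 percentage points lower from compound 2 to compound 3 (within the scatter) swaps one replacement for another. Every one of them stays within the scatter, so no step beyond the scatter is expected here either; the expected step is a number 1.5 percentage points higher from compound 1 to compound 4 (within the scatter). Compound 4 is therefore estimated at 3%, with a range from 0% to 12%.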

Compound 4, largest response reached (reported as efficacy), in percent of the reference or control that the assay uses: 1.9%
Estimate against measurement, compound 4: 1.1 percentage points above, and the stated range covers the measured number.
By their numbers in this assay, from the lowest: compounds 1, 4, 3 and 2 (each within the scatter of the next).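

In this assay, the new group on the carbonyl carbon, ((tert-butoxycarbonyl)amino)amino, is larger than ethoxy and brings hydrogen-bond donors, yet the response does not separate (a number 0.4 percentage points higher from compound 1 to compound 4 (within the scatter)). It also stays within the scatter of the two amides (a number 1 percentage points lower from compound 3 to compound 4 (within the scatter); a number 1.7 percentage points lower from compound 2 to compound 4 (within the scatter)), so this position has now tolerated a wider range of groups with no measurable change. Nothing available explains this. Still open, on these data alone, is whether a carboxylic acid or a piperidine amide on that carbonyl carbon would change the response.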